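Replacing a methoxymethyl with isopropyl on the side chain

This account rests on a few compounds, and the source may have more. Where it says the series, first, only, none or still open, it means among the compounds named here.

Compound 3 `COCCCn1c(N2CCN(C)CC2)nc2ccccc21` stands at the top of the numbers gathered so far: in a functional assay on ileum for inhibition of histamine H1 receptor (Cavia porcellus) (on this read-out higher numbers stand for weaker inhibition and lower numbers for stronger inhibition), compound 3 gives 860 nM. Its nearest neighbour is compound 2 `CN1CCN(c2nc3ccccc3n2-c2ccccc2)CC1`, which in this assay gives 760 nM; the step of a 1.1-fold higher number from compound 2 to compound 3 (0.05 log units; within the scatter) lies within the scatter. Furthest away is compound 1 `CN1CCN(c2nc3ccccc3n2CCOCCO)CC1`, which in this assay gives 42 nM, so that a 20-fold higher number from compound 1 to compound 3 (1.31 log units; beyond the scatter) and an 18-fold higher number from compound 1 to compound 2 (1.26 log units; beyond the scatter) are both large steps toward weaker inhibition. The next compound is compound 4 `CC(C)CCn1c(N2CCN(C)CC2)nc2ccccc21`, which differs from compound 3 by isopropyl in place of methoxymethyl on a saturated chain carbon, two bonds along the chain from an aromatic nitrogen. The step that bears most directly on it is a 20-fold higher number from compound 1 to compound 3 (1.31 log units; beyond the scatter), where trimming 2-hydroxyethoxy to methoxymethyl cost a great deal; compound 4 goes one stage further and keeps no hydrogen-bond acceptor in the chain. The step of a 1.1-fold higher number from compound 2 to compound 3 (0.05 log units; within the scatter) shows that a chain without a hydroxyl and a phenyl come out alike. Compound 4 is therefore expected to show a small move toward weaker inhibition or none beyond the scatter, a 1.4-fold higher number from compound 3 to compound 4 (0.14 log units; within the scatter), and its value in this assay is estimated at 1200 nM, between 400 nM and 4000 nM.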

Compound 4, half-maximal inhibitory concentration: 1400 nM
Estimate against measurement, compound 4: 1.2-fold (0.07 log units) below; measured number inside the range.
By their numbers in this assay, from the lowest: compound 1; then compounds 2, 3 and 4 (each within the scatter of the next).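

Replacing methoxymethyl with isopropyl gives in this assay a 1.6-fold higher number from compound 3 to compound 4 (0.21 log units; within the scatter) and so no change that can be told from the scatter, which means the chain oxygen of compound 3 carries no measurable weight at this position. Set against phenyl, the isopentyl chain gives a 1.8-fold higher number from compound 2 to compound 4 (0.27 log units; within the scatter) and again stays within the scatter, so compound 2, compound 3 and compound 4 sit together in one band. Only compound 1 stands apart, with a 33-fold higher number from compound 1 to compound 4 (1.52 log units; beyond the scatter) as a large step, so among these chains the low number goes with 2-hydroxyethoxy alone and not with any chain oxygen as such.

Nothing available explains this gap. Going by these compounds, whether the end hydroxyl or the chain length carries it stays open: a chain ending in methoxy, an amine or a carboxylic acid in place of that hydroxyl would separate the two.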